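Compound 1 to compound 4: moving the two fluorines

This account rests on a few compounds, and the source may have more. Where it says the series, first, only, none or still open, it means among the compounds named here.

Measured in an ADME assay on LLC-MK2 cells (Macaca mulatta) for cytotoxicity, read by spectrophotometry and crystal violet staining, with a stated time of 4 days; a lower number here means that less compound is tolerated, a higher number that more compound is tolerated:
- compound 1 `CC(C)n1ncc2c(C(=O)Nc3c(F)cccc3F)cc(-c3cccs3)nc21`: > 200000 nM (a limit)
- compound 2 `CC(C)n1ncc2c(C(=O)Nc3ccccn3)cc(C3CC3)nc21`: 25000 nM
- compound 3 `CC(C)n1ncc2c(C(=O)Nc3ccccc3F)cc(-c3ccccn3)nc21`: 100000 nM

Compound 1 gives only a limit and not a number: the limit of > 200000 nM in this assay, at which 1 of the 3 values shown sits. Among the measured compounds shown here, compound 2 reads 25000 nM and compound 3 reads 100000 nM, but no two measured compounds differ in one place only, so no measured step bears directly on the change at hand.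

Compound 4 `CC(C)n1ncc2c(C(=O)Nc3ccc(F)c(F)c3)cc(-c3cccs3)nc21` keeps the core of compound 1 and carries 3,4-difluorophenyl in place of 2,6-difluorophenyl on an amide-type nitrogen.

For the measured compounds named here, with no matched step to go on, the expectation is loose. The step expected is an at least 2.0-fold lower number from compound 1 to compound 4 (0.30 log units; that floor lies within the scatter), a modest move towards less compound tolerated, or none that can be seen if the reading is again a limit. The working anchor is compound 3 at 100000 nM. For compound 4 the estimated value is 100000 nM, with an expected range of 30000 nM to 200000 nM.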

Compound 4, half-maximal cytotoxic concentration: > 200000 nM
Compound 4: a limit, no number; the forecaster's own chance of this, stated with the estimate: 35%; at least 2.0-fold (0.30 log units) between middle value and limit.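

Compound 1 and compound 4 both read as limits and not as numbers, so no step can be read between them: the limit of > 200000 nM in this assay, at which 2 of the 4 values shown sit.

The compounds shown leave open whether 3,4-difluorophenyl in place of 2,6-difluorophenyl changes the tolerated concentration at all in this assay.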